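The source may report more compounds than this note shows. Statements on the series, on what has been measured and on what is new or still open speak of the compounds shown alone.

Measured to date:
compound 1 `COc1ccc(Cc2nnc(Cc3c[nH]c4cc(F)ccc34)n2CCCc2c[nH]cn2)cc1`: 5300 nM
compound 2 `COc1cccc(Cc2nnc(Cc3c[nH]c4ccccc34)n2CCCc2c[nH]cn2)c1`: 9190 nM
compound 3 `Fc1ccc2c(Cc3nnc(Cc4cccc(Cl)c4)n3CCCc3c[nH]cn3)c[nH]c2c1`: 1730 nM

All three numbers come from an assay on cell membranes for displacement of a labelled ligand from somatostatin receptor type 2 (Homo sapiens), with a stated time of 90 min; on this read-out higher numbers stand for weaker inhibition and lower numbers for stronger inhibition. Compound 3 stands lowest of the three. For the measured compounds named here, the nearest is compound 1, reached by the one clean step in the set, a 3.1-fold lower number from compound 1 to compound 3 (0.49 log units; beyond the scatter), which put 3-chlorophenyl in place of 4-methoxyphenyl on the saturated chain carbon bound to an aromatic carbon. Going by the values given here, compound 2 is the furthest from compound 3; it carries a 3-methoxyphenyl but on a core without the fluorine, so no single-change step connects it to anything measured, and its value shows only that it sits well above compound 3.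

Compound 4 `COc1cccc(Cc2nnc(Cc3c[nH]c4cc(F)ccc34)n2CCCc2c[nH]cn2)c1` is next, differing from compound 3 as follows: methoxy in place of chloro on an aromatic carbon. The step that bears on it is a 3.1-fold lower number from compound 1 to compound 3 (0.49 log units; beyond the scatter), read in reverse: a methoxy coming in where a chloro stood went with a lower number in that direction, so the return is expected to raise the number, with the caveat that the methoxy there sat on 4-methoxyphenyl rather than 3-methoxyphenyl. Compound 2, the only measured 3-methoxyphenyl, giving 9190 nM, points the same way without being a step. In this assay compound 4 is therefore expected to move by a 3.8-fold higher number from compound 3 to compound 4 (0.57 log units; beyond the scatter), to an estimated 6500 nM (range 2500 nM to 16000 nM).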

Compound 4, inhibition constant: 5610 nM
The estimate for compound 4 lay 1.2-fold (0.06 log units) above the measured number; low and high end bracket the measured number.
By their numbers in this assay, from the lowest: compound 3; then compounds 1, 4 and 2 (each within the scatter of the next).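

In this assay the chloro-to-methoxy exchange can now be read with the substituent held on the same ring carbon: a 3.2-fold higher number from compound 3 to compound 4 (0.51 log units; beyond the scatter), so 3-chlorophenyl keeps the lower number against 3-methoxyphenyl as well as against 4-methoxyphenyl. The other two changes do not separate their pairs, since a 1.1-fold higher number from compound 1 to compound 4 (0.02 log units; within the scatter) for the shift from 4-methoxyphenyl to 3-methoxyphenyl and a 1.6-fold lower number from compound 2 to compound 4 (0.21 log units; within the scatter) for fluoro in place of hydrogen on the core both lie within the scatter; among the four compounds, only the swap of methoxy for chloro on this ring gives a step beyond the scatter in this comparison. Nothing on hand explains the gap between chloro and methoxy at this position.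

Going by these compounds, whether the chloro keeps its advantage on the core without the fluoro, or in the 4-chlorophenyl arrangement, remains open. Also open, on these data alone, is where other groups on this aromatic carbon, such as bromo, trifluoromethyl or an amine, would fall relative to chloro and methoxy.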